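A few compounds are considered here, and "the series" means these few. Any claim that something is new, unique, unknown or untested is made for them only; others in the source may bear on it.

Compound 1 `COc1ccc(OCC(=O)N2CCN(c3ccc(C(F)(F)F)cc3[C@@H](N)CC(C)C)CC2)cc1` gives 3800 nM in an assay on HEK293 cells for displacement of a labelled ligand from Melanocortin receptor 4 (Homo sapiens) (on this read-out higher numbers stand for weaker inhibition and lower numbers for stronger inhibition), the highest of the three numbers measured. Compound 2 `CC(C)C[C@H](N)c1cc(C(F)(F)F)ccc1N1CCN(C(=O)C(C)Cc2ccc(Cl)cc2)CC1` gives 47 nM, and compound 3 `COc1cc(Cl)ccc1C[C@@H](C)C(=O)N1CCN(c2ccc(C)cc2[C@@H](N)CC(C)C)CC1` gives 8.1 nM. Within the data shown here, the one measured step from compound 1, an 81-fold lower number from compound 1 to compound 2 (1.91 log units; beyond the scatter), put 1-(4-chlorobenzyl)ethyl in place of (4-methoxyphenoxy)methyl and so kept an aromatic ring on the amide side. Compound 4 `CC(C)C[C@H](N)c1cc(C(F)(F)F)ccc1N1CCN(C(=O)CCC(=O)N(C)C)CC1` differs from compound 1 as follows: (dimethylcarbamoyl)methyl in place of 4-methoxyphenoxy on a saturated chain carbon bound to a carbonyl carbon. Among the measured compounds shown here, no measured step covers the loss of the aromatic ring on that side; compounds 2 and 3 both retain one. With compound 1 already at the high end, compound 4 is expected to stay near it or move higher, a 2.1-fold higher number from compound 1 to compound 4 (0.32 log units; beyond the scatter). Compound 4 is estimated at 8000 nM, within 2000 nM to 40000 nM.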

Compound 4, inhibition constant: > 10000 nM
Compound 4: a limit, no number (the forecaster's own chance of this, stated with the estimate: 30%); at least 1.2-fold (0.09 log units) between middle value and limit.
By their numbers in this assay, from the lowest: compound 3; then compound 2; then compound 1. At a limit, above all of these: compound 4.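

Compound 4 gives > 10000 nM, which is a limit of the assay and not a number. It is the first compound shown with no ring on the chain at the carbonyl carbon, and the change from 4-methoxyphenoxy to (dimethylcarbamoyl)methyl gives an at least 2.6-fold higher number from compound 1 to compound 4 (0.42 log units; beyond the scatter). The comparison with the chlorinated chain is wider, an at least 210-fold higher number from compound 2 to compound 4 (2.32 log units; beyond the scatter), so a ring-free chain sits at the weak end, although compound 1 shows that keeping an aromatic ring does not by itself give a low number.

The compounds shown leave open whether the lost ring or the entering dimethylcarbamoyl group matters more. A plain alkyl chain, or a chain ending in an amine or a carboxylic acid, at this place would bear on that.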